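A few compounds are considered here, and "the series" means these few. Any claim that something is new, unique, unknown or untested is made for them only; others in the source may bear on it.

Measured in a functional assay on cells (T-cell, Homo sapiens) for inhibition; on this read-out higher numbers stand for weaker inhibition and lower numbers for stronger inhibition:
compound 1 `COc1ccc(-c2cnc3nc(N)nc(N4CCN(C(=O)COc5ccccc5)CC4)c3n2)cc1OC` gives 4 nM
compound 2 `COc1ccc(-c2cnc3nc(N)nc(NC(C)C)c3n2)cc1OC` gives 600 nM
compound 3 `Cc1ccc(-c2cnc3nc(N)nc(OC(C)C)c3n2)cc1C` gives 10000 nM

Compound 1 stands lowest of the three numbers in this assay; the values of compound 2 and of compound 3 both lie beyond the scatter from it, compound 3 furthest. Within the data shown here, no pair among the measured compounds differs in a single place, so no measured step exists for comparison.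

Compound 4 `COc1ccc(-c2cnc3nc(N)nc(N4CCN(C(=O)CCc5ccccc5)CC4)c3n2)cc1OC` differs from compound 1 in one place:
benzyl in place of phenoxy on a saturated chain carbon bound to a carbonyl carbon
The phenoxy leaves and the benzyl enters on the saturated chain carbon bound to the carbonyl carbon. Among the measured compounds shown here, no measured step of this kind is available. The step from compound 1 to compound 4 in this assay is expected to be a 1.5-fold higher number from compound 1 to compound 4 (0.18 log units; within the scatter), none beyond the scatter or at most a small weakening. For compound 4 the estimate in this assay is 6 nM, within 1.5 nM to 25 nM.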

Compound 4, half-maximal inhibitory concentration: 100 nM
Compound 4: middle estimate off by 17-fold (1.22 log units), on the low side; measured number above the stated range.
By their numbers in this assay, from the lowest: compound 1; then compound 4; then compound 2; then compound 3.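

In this assay, among these compounds, benzyl in place of phenoxy on a saturated chain carbon bound to a carbonyl carbon gives a 25-fold higher number from compound 1 to compound 4 (1.40 log units; beyond the scatter), a large step and the first measured change at this place. The two groups match in heavy-atom count and in their aromatic ring, and only phenoxy carries a hydrogen-bond acceptor, so this place responds strongly even where those counts barely differ. No measurement here ties the step to any property of either group.

From the compounds shown here alone, whether an anilino or a thiophenyl group at this place would stay close to compound 1 remains open. So does the effect of a longer chain.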